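Swapping the aryl group on the piperazine of compound 3

This account rests on a few compounds, and the source may have more. Where it says the series, first, only, none or still open, it means among the compounds named here.

Three compounds share one core and were tested in a functional assay on aorta for antagonist activity at Alpha-1D adrenergic receptor (Rattus norvegicus); a lower number here means tighter binding, a higher number weaker binding. Compound 1 `CN(C)C(=O)c1cccnc1NCCCN1CCN(c2ccccc2)CC1` gives 15.9 nM, compound 2 `CN(C)C(=O)c1cccnc1NCCCN1CCN(c2ccccc2C#N)CC1` gives 10 nM, and compound 3 `CC(C)c1ccccc1N1CCN(CCCNc2ncccc2C(=O)N(C)C)CC1` gives 63.1 nM, the highest of the three numbers; the steps of a 4.0-fold higher number from compound 1 to compound 3 (0.60 log units; beyond the scatter) and a 6.3-fold higher number from compound 2 to compound 3 (0.80 log units; beyond the scatter) both lie beyond the scatter. Compound 4 `COc1cc(C)ccc1N1CCN(CCCNc2ncccc2C(=O)N(C)C)CC1` carries 2-methoxy-4-methylphenyl in place of 2-isopropylphenyl on an amine nitrogen in a ring. The step from compound 1 to compound 3 bears most directly, since the isopropyl that entered there now leaves again; the step from compound 2 to compound 3 points the same way. Among the measured compounds shown here, a drop in this assay of roughly that size is therefore expected, though the entering methoxy and methyl have no measured precedent here, so the range is wide. Compound 4 is estimated at 25 nM, between 8 nM and 80 nM, a step of a 2.5-fold lower number from compound 3 to compound 4 (0.40 log units; beyond the scatter).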

Compound 4, dissociation constant: 39.8 nM
For compound 4 the middle estimate is 1.6-fold (0.20 log units) below the measured one; measured number inside the range.
By their numbers in this assay, from the lowest: compounds 2 and 1 (each within the scatter of the next); then compounds 4 and 3 (each within the scatter of the next).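

In this assay, putting 2-methoxy-4-methylphenyl in place of 2-isopropylphenyl gives a 1.6-fold lower number from compound 3 to compound 4 (0.20 log units; within the scatter), so at this position on the ring nitrogen the two groups cannot be told apart, even though only the entering group counts a hydrogen-bond acceptor. The same group gives a 2.5-fold higher number from compound 1 to compound 4 (0.40 log units; beyond the scatter) and a 4.0-fold higher number from compound 2 to compound 4 (0.60 log units; beyond the scatter), so it does not match plain phenyl or 2-cyanophenyl here. No supporting data explain these differences.
As far as these compounds go, it remains open how the methoxy and the methyl each contribute, and whether a 2-methoxyphenyl group alone would fall nearer compound 1 or compound 4.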